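A few compounds are considered here, and "the series" means these few. Any claim that something is new, unique, unknown or untested is made for them only; others in the source may bear on it.

Measured compounds:

Compound 1, `COc1cc(OC)c2sc(-c3ccc(N/C=C\C(=O)c4ccc(OC)c(O)c4)c(C)c3)nc2c1`, gives 22100 nM.
Compound 2, `COc1ccc2nc(-c3ccc(N/C=C\C(=O)c4ccc(OC)c(O)c4)c(C)c3)sc2c1`, gives 17000 nM.
Compound 3, `COc1cc(OC)c2sc(-c3ccc(N/C=C\C(=O)c4ccc(OC)c(O)c4)cc3)nc2c1`, gives 11600 nM.

All three were tested in a functional assay on MIA PaCa-2 cells (Homo sapiens) for antiproliferative activity, read by sulforhodamine B assay, with a stated time of 48 h; a higher number here means a weaker inhibitor, a lower number a stronger inhibitor. Compound 1 and compound 3 share a core and differ in one place: hydrogen in place of methyl on an aromatic carbon. That change produced a 1.9-fold lower number from compound 1 to compound 3 (0.28 log units; within the scatter), so among these compounds it left the readout essentially where it was. Compound 2 carries a different core; the difference between the two cores is not broken down here. Compound 2 sits close to compound 1 and to compound 3, and all three values lie within the scatter of one another.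

Compound 4, `COc1ccc2nc(-c3ccc(N/C=C\C(=O)c4ccc(OC)c(O)c4)cc3)sc2c1`, has not yet been measured in this assay. It stands to compound 2 as compound 3 stands to compound 1: hydrogen in place of methyl on an aromatic carbon. The place is described in the same words for both pairs, so this is the same change made on the other core. Among the compounds with values here, the only guide to its size is the one earlier example, a 1.9-fold lower number from compound 1 to compound 3 (0.28 log units; within the scatter), which stayed within the scatter. The expectation for compound 4 therefore rests on that single pair and on the value of compound 2, 17000 nM.

On that basis the step from compound 2 to compound 4 is expected to be about a 1.8-fold lower number from compound 2 to compound 4 (0.25 log units; within the scatter). Compound 4 is accordingly estimated to give 9500 nM, with a plausible range from 4500 nM to 20000 nM.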

Compound 4, half-maximal inhibitory concentration: 21900 nM
The estimate for compound 4 lay 2.3-fold (0.36 log units) below the measured number; the measured number lies above the stated range.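

In this assay, hydrogen in place of methyl on the aromatic carbon of the second core gave a 1.3-fold higher number from compound 2 to compound 4 (0.11 log units; within the scatter), so on this core too the change left the readout within the scatter. Set beside the earlier step, this one does not differ from it by more than two such steps can differ on their own: the same change on two cores in this assay, a 1.9-fold lower number (0.28 log units; within the scatter) from compound 1 to compound 3 and a 1.3-fold higher number (0.11 log units; within the scatter) from compound 2 to compound 4, 2.5-fold (0.39 log units) apart, within the scatter of two such steps. Within the data shown here, the two pairs therefore agree that this change can be carried from one core to the other without a readable effect, but they do not show that it has a fixed size or direction, as both steps are small and each core offers only a single pair.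

The compounds shown leave open whether a group other than methyl or hydrogen on this aromatic carbon, such as a chlorine atom, an amine or a carboxylic acid, would shift the number on either core beyond the scatter. They also leave open whether the near silence of this change holds on any core beyond these two, or in any read-out other than this assay.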